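This account rests on a few compounds, and the source may have more. Where it says the series, first, only, none or still open, it means among the compounds named here.

Compound 1, `CCOC(=O)c1c(C)oc2ncnc(Nc3ccccc3)c12`: in a functional assay on A549 cells (Homo sapiens) for cytotoxicity, read by MTT assay, with a stated time of 72 h (on this read-out lower numbers stand for stronger inhibition and higher numbers for weaker inhibition), compound 1 gives > 1000000 nM, a limit of the assay rather than a number.
Compound 2, `Cc1oc2ncnc(Nc3cccc(Br)c3)c2c1C(=O)NCCO`: in this assay compound 2 gives 17400 nM.
Compound 3, `CCOC(=O)c1c(C)oc2ncnc(Nc3cccc(Br)c3)c12`: in this assay compound 3 gives > 1000000 nM, again a limit of the assay.

Compound 3 therefore stands at the weak end of the numbers shown, at the limit of > 1000000 nM in this assay, at which 2 of the 3 values shown sit. Two measured steps lead to it. From compound 1, a step that the two limits leave unreadable from compound 1 to compound 3, so that change tells nothing here. From compound 2, an at least 57-fold higher number from compound 2 to compound 3 (1.75 log units; beyond the scatter), so swapping the amide for the ethyl ester loses a great deal of cytotoxic potency.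

Compound 4, `Cc1oc2ncnc(Nc3cccc(Br)c3)c2c1CO`, is not yet measured. Relative to compound 3 the change is hydroxymethyl in place of ethoxycarbonyl on an aromatic carbon. Within the data shown here, the only step that bears on it is the one from compound 2 to compound 3, which shows that the ethyl ester is the weak group; hydroxymethyl, like the (2-hydroxyethyl)amino group of compound 2, brings one hydrogen-bond donor. A lower number than the limit of compound 3 is therefore expected, though how much lower cannot be read from the data. Compound 4 is estimated at 150000 nM in this assay, between 20000 nM and 1000000 nM, an expected step of an at least 6.6-fold lower number from compound 3 to compound 4 (0.82 log units; beyond the scatter).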

Compound 4, half-maximal inhibitory concentration: 102000 nM
Compound 4: the middle estimate sits 1.5-fold (0.17 log units) above what was measured; the range from low to high includes it.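

Replacing ethoxycarbonyl with hydroxymethyl on this aromatic carbon gives an at least 9.8-fold lower number from compound 3 to compound 4 (0.99 log units; beyond the scatter), so a group with no carbonyl can still give a measurable value in this assay. Hydroxymethyl does not match the longer amide group, however, with a 5.9-fold higher number from compound 2 to compound 4 (0.77 log units; beyond the scatter), so among the bromo compounds shown, the (2-hydroxyethyl)carbamoyl group of compound 2 gives the lowest number. Compound 1 and compound 3, both ethyl esters, are the only compounds that stop at a limit rather than a number: the limit of > 1000000 nM in this assay, at which 2 of the 4 values shown sit.

The compounds shown leave open which part of the (2-hydroxyethyl)carbamoyl group accounts for its lower number, the carbonyl-linked amide or the hydroxyethyl chain. A carboxylic acid, a plain unsubstituted amide or an aminomethyl group on the same carbon would help to separate these parts.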